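This account rests on a few compounds, and the source may have more. Where it says the series, first, only, none or still open, it means among the compounds named here.

Measured compounds:
compound 1 `O=c1c2ccccc2c(-c2cccnc2)nn1Cc1cccc(Cl)c1` — 4170 nM
compound 2 `COC(=O)c1ccc(Cn2nc(-c3cccnc3)c3ccccc3c2=O)cc1` — 5890 nM
compound 3 `O=c1c2ccccc2c(-c2cccnc2)nn1S(=O)(=O)c1ccccc1` — 14800 nM

In a functional assay (trachea) with Cavia porcellus as the target (a higher number here means a weaker inhibitor, a lower number a stronger inhibitor), compound 1 gives the lowest number of the three, though its gap to compound 2 lies within the scatter, and only compound 3 sits beyond it. Compound 4 `O=c1c2ccccc2c(-c2cccnc2)nn1CCO` has not been measured. It differs from compound 1 in one place: hydroxymethyl in place of 3-chlorophenyl on a saturated chain carbon bound to an aromatic nitrogen. No step between measured compounds covers a change of this kind, so nothing shown gives a direct guide to its size. The two measured variations at this position, in compound 2 and compound 3, both return higher numbers than compound 1 in this assay, so a move toward a weaker result is expected, with the step from a 3.6-fold higher number from compound 1 to compound 4 (0.56 log units; beyond the scatter) estimated as moderate. Compound 4 is therefore expected to give about 15000 nM, within a range of 4000 nM to 55000 nM.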

Compound 4, half-maximal inhibitory concentration: 4570 nM
Estimate against measurement, compound 4: 3.3-fold (0.52 log units) above; measured number inside the range.
By their numbers in this assay, from the lowest: compounds 1, 4 and 2 (each within the scatter of the next); then compound 3.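

In this assay the change from 3-chlorobenzyl to 2-hydroxyethyl barely registers (a 1.1-fold higher number from compound 1 to compound 4 (0.04 log units; within the scatter)), so the 3-chlorophenyl group can leave this place without a shift beyond the scatter. For the compounds shown here, the earlier compounds all carried an aromatic ring here, and this result is the first sign that such a ring is not required. Nothing given bears on why the two groups read alike. The compounds shown leave open whether the hydroxyl of the 2-hydroxyethyl group counts at all, which a plain ethyl group would test, and how an amine, a carboxylic acid or a longer chain would read here.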